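Amide variation on the aryloxyacetamide of the butylbenzofuran series

The source may hold more compounds than are shown below. What is called first, only, known or untested is meant among the compounds shown, and "the series" means these compounds.

Compound 2 `CCCCc1oc2ccccc2c1C(=O)c1ccc(OCC(=O)N2CCOCC2)cc1` gives 45400 nM in a functional assay on U-937 cells (Homo sapiens) for antiproliferative activity, read by MTT assay, with a stated time of 24 h (on this read-out lower numbers stand for stronger inhibition and higher numbers for weaker inhibition), the higher of the two numbers recorded so far; compound 1 `CCCCc1oc2ccccc2c1C(=O)c1ccc(OCC(N)=O)cc1` gives 42200 nM, within the scatter of it. Compound 3 `CCCCc1oc2ccccc2c1C(=O)c1ccc(OCC(=O)N[C@H](C)c2ccccc2)cc1` carries (1-phenylethyl)amino in place of morpholin-4-yl on a carbonyl carbon. Among the compounds with values here, the only step that bears on this change is a 1.1-fold higher number from compound 1 to compound 2 (0.03 log units; within the scatter), so the amide substituent has so far moved the read-out not at all. No shift beyond the scatter is therefore expected, and compound 3 is estimated at 40000 nM, between 18000 nM and 90000 nM, a step of a 1.1-fold lower number from compound 2 to compound 3 (0.05 log units; within the scatter) from compound 2.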

Compound 3, half-maximal inhibitory concentration: 19800 nM
Compound 3: middle estimate off by 2.0-fold (0.31 log units), on the high side; measured number inside the range.
By their numbers in this assay, from the lowest: compound 3; then compounds 1 and 2 (each within the scatter of the next).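

The amide substituent on the carbonyl carbon can move the read-out in this assay: (1-phenylethyl)amino in place of morpholin-4-yl gives a 2.3-fold lower number from compound 2 to compound 3 (0.36 log units; beyond the scatter), and 1-phenylethyl in place of hydrogen on the amide-type nitrogen gives a 2.1-fold lower number from compound 1 to compound 3 (0.33 log units; beyond the scatter). Both steps are modest, yet unlike the earlier amino to morpholin-4-yl step, they lie beyond the scatter. Nothing available accounts for the shift.

Still open, on these data alone, is which part of the 1-phenylethyl group carries the shift, the phenyl ring, the methyl branch or the defined stereocentre. A benzylamino group, a methylamino group or the opposite enantiomer would separate these.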